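Series notes: bromo in place of fluoro

A few compounds are considered here, and "the series" means these few. Any claim that something is new, unique, unknown or untested is made for them only; others in the source may bear on it.

Measured in a functional assay on K562 cells (Homo sapiens) for cytotoxicity, read by MTT assay, with a stated time of 24 h; on this read-out lower numbers stand for stronger inhibition and higher numbers for weaker inhibition:
- compound 1 `COc1cc(/C=C2\CN(C)C/C(=C\c3ccc(C#N)cc3)C2=O)cc(OC)c1`: 4650 nM
- compound 2 `CN1C/C(=C\c2ccc(F)cc2)C(=O)/C(=C/c2ccc(C#N)cc2)C1`: 11300 nM

Of these two, compound 2 has the higher number and so the weaker inhibition, and the gap to compound 1 lies beyond the scatter. Compound 3 `CN1C/C(=C\c2ccc(Br)cc2)C(=O)/C(=C/c2ccc(C#N)cc2)C1` is the next to be read. It carries bromo in place of fluoro on an aromatic carbon, para to a large group (bromo in place of fluoro on an aromatic carbon), with 4-fluorophenyl becoming 4-bromophenyl.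

Within the data shown here, no measured pair shows this exchange, so the expectation in this assay starts from compound 2 at 11300 nM. A small move towards a lower number is expected, probably not beyond the scatter. The estimated change is a 1.4-fold lower number from compound 2 to compound 3 (0.15 log units; within the scatter). The expected value for compound 3 is 8000 nM, with an estimated range of 3500 nM to 16000 nM.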

Compound 3, half-maximal inhibitory concentration: 7420 nM
Estimate against measurement, compound 3: 1.1-fold (0.03 log units) above; the range from low to high includes it.
By their numbers in this assay, from the lowest: compounds 1, 3 and 2 (each within the scatter of the next, the first and the last beyond it).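

In this assay, among these compounds, bromo in place of fluoro gives a 1.5-fold lower number from compound 2 to compound 3 (0.18 log units; within the scatter), the first reading of any exchange at this position. On an aromatic carbon para to a large group, the two halogens therefore cannot be told apart on this read-out, and 4-bromophenyl serves as well as 4-fluorophenyl with the rest of the compound unchanged. Nothing available here gives a reason for this result.

Open, as far as these compounds go, is whether a group other than a halogen, such as an amine or a carboxylic acid, would also stay within the scatter of compound 2 at this same place. Also open, from the compounds shown here alone, is whether bromo and fluoro would still read alike with the nitrile on the other aromatic ring replaced by another group.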